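Removing the Fluorine from a Benzothiazole Pair

The source may hold more compounds than are shown below. What is called first, only, known or untested is meant among the compounds shown, and "the series" means these compounds.

Within the data shown here, compound 1 `CCOc1ccc2nc(Nc3nc4ccc(F)cc4s3)sc2c1` is the only member of this small set with a measured number: in a functional assay on U-937 cells (Homo sapiens) for cytotoxicity, read by MTT assay, with a stated time of 48 h (a higher number here means a weaker inhibitor, a lower number a stronger inhibitor), compound 1 gives 26600 nM. Compound 2 `Cc1ccc2nc(Nc3nc4ccc(F)cc4s3)sc2c1` reaches only a limit of the assay, giving > 50000 nM in this assay. Compound 3 `S=C(Nc1ccccc1)Nc1nc2ccccc2s1`, which joins its two ring systems through a different linker, also stops at a limit, giving > 50000 nM in this assay. Hence (the limit of > 50000 nM in this assay, at which 2 of the 3 values shown sit), and compound 1 is the only point from which a change can be read in numbers.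

Among the measured compounds shown here, the single measured step, an at least 1.8-fold higher number from compound 1 to compound 2 (0.27 log units; that floor lies within the scatter), exchanges ethoxy for methyl and lies at the edge of the scatter; it says nothing about fluorine.

Compound 4 `CCOc1ccc2nc(Nc3nc4ccccc4s3)sc2c1` keeps the ethoxy of compound 1 and differs from it by hydrogen in place of fluoro on an aromatic carbon. For the measured compounds named here, no measured step touches this change, so the expectation rests on compound 1 alone, together with the fact that most of the series lands at the floor of the assay. A step of a 1.3-fold higher number from compound 1 to compound 4 (0.12 log units; within the scatter) is expected, which stays within the scatter. Compound 4 is therefore estimated at 35000 nM in this assay, with a likely range from 12000 nM to 100000 nM, and a real chance that only a limit is reported.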

Compound 4, half-maximal inhibitory concentration: > 50000 nM
Compound 4: only a limit was reported; the forecaster's own chance of this, stated with the estimate: 40%; middle value at least 1.4-fold (0.15 log units) from the limit.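

Among these compounds, this is the first view of the fluoro position itself: with the ethoxy kept in place, hydrogen in place of fluoro on the aromatic carbon gives an at least 1.8-fold higher number from compound 1 to compound 4 (0.27 log units; that floor lies within the scatter) in this assay and does not show that the fluorine matters. On these data alone, the result for compound 4 is a limit of the assay, not a number, so the true size of this change remains unknown and the step cannot be told apart from ordinary scatter. Even so, a single change away from compound 1 now ends at the limit at two different places, the ethoxy in compound 2 and the fluoro in compound 4, and compound 1 remains the only measured point: the limit of > 50000 nM in this assay, at which 3 of the 4 values shown sit.

Whether any other group at the fluoro position could give a measured number stays open, for example a chlorine atom, a methoxy group or an amine, since the compounds shown hold only fluoro or hydrogen there. A replacement that gave a clearly lower number than compound 1 would be needed to show whether this position can influence the result at all.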